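Cyclopentyl in place of cyclopropyl on the sulfonamide nitrogen

A few compounds are considered here, and "the series" means these few. Any claim that something is new, unique, unknown or untested is made for them only; others in the source may bear on it.

Measured so far in an assay on Sf9 cells for inhibition of protein deacetylase HDAC6 (Homo sapiens), read by fluorescence and mobility shift assay; on this read-out lower numbers stand for stronger inhibition and higher numbers for weaker inhibition:
Compound 1, `O=C(NO)c1ccc(CN(C2CC2)S(=O)(=O)c2cc(F)c(F)c(F)c2F)cc1`: compound 1 gives 8.5 nM
Compound 2, `CC(C)N(Cc1ccc(C(=O)NO)cc1)S(=O)(=O)c1c(F)c(F)c(F)c(F)c1F`: compound 2 gives 4.32 nM
Compound 3, `CC(C)N(Cc1ccc(C(=O)NO)cc1)Cc1cc(F)c(F)c(F)c1F`: compound 3 gives 16.2 nM

Compound 1 lies between compound 2 and compound 3 on the numbers shown, and each gap is within the scatter of repeated measurements, so the three numbers show no order that can be read. Among the compounds with values here, the three structures also differ from one another in more than one place, so no single step can be drawn between any two of them.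

Compound 4, `O=C(NO)c1ccc(CN(C2CCCC2)S(=O)(=O)c2cc(F)c(F)c(F)c2F)cc1`, has not yet been measured in this assay. It differs from compound 1 only in cyclopentyl in place of cyclopropyl on a sulfonamide nitrogen. Within the data shown here, no pair of measured compounds carries this change or one like it, so no measured step guides the expectation; the rest of the molecule is kept unchanged. The step from compound 1 to compound 4 is expected to be a 1.1-fold lower number from compound 1 to compound 4 (0.03 log units; within the scatter), that is, no change beyond the scatter in either direction. Among the measured compounds shown here, compound 4 is therefore expected to give 8 nM in this assay, within a range of 3 nM to 25 nM, the range kept wide since no comparable step is known.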

Compound 4, half-maximal inhibitory concentration: 49.9 nM
For compound 4 the middle estimate is 6.2-fold (0.80 log units) below the measured one, outside the stated range (above it).
By their numbers in this assay, from the lowest: compounds 2, 1 and 3 (each within the scatter of the next, the first and the last beyond it); then compound 4.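

Working from this assay, cyclopentyl in place of cyclopropyl on the sulfonamide nitrogen gives a 5.9-fold higher number from compound 1 to compound 4 (0.77 log units; beyond the scatter), with the rest of the molecule unchanged. Within the data shown here, this is the first measured single-place step, and it shows that the group on this nitrogen can by itself move the number beyond the scatter, in the direction of weaker inhibition. The earlier compounds could not show this, as they differ from one another in more than one place and no step could be drawn between them, while the data given here offer nothing that bears on the cause of this step.

A single step with only the cyclopropyl and cyclopentyl rings leaves open whether the number rises steadily with ring size or whether the cyclopentyl result stands alone, a question that cyclobutyl or cyclohexyl on the same nitrogen, with the core of compound 1 kept, would address. From the compounds shown here alone, it also remains open how this position responds to a group of a different kind, such as a methyl, a straight butyl chain, or a chain ending in a primary amine or a carboxylic acid.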